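Cutting back the chain of compound 3

The source may report more compounds than this note shows. Statements on the series, on what has been measured and on what is new or still open speak of the compounds shown alone.

Compound 1 `COC(=O)c1c[nH]c2ccccc2c1=O`: > 20000 nM (a limit of the assay)
Compound 2 `COC(=O)c1c[nH]c2ccc(OCc3ccccc3)cc2c1=O`: 7590 nM
Compound 3 `COC(=O)c1c[nH]c2ccc(OCCCc3ccccc3)cc2c1=O`: 17100 nM

These results come from an ADME assay on J774 cells (Mus musculus) for cytotoxicity; on this read-out lower numbers stand for an effect already at smaller amounts and higher numbers for an effect only at larger amounts of compound. Of the two exact numbers, compound 3 has the higher at 17100 nM, and the nearest is compound 2 at 7590 nM. For compound 1 the result > 20000 nM is a limit, not a number.

The next compound is compound 4 `CCOc1ccc2[nH]cc(C(=O)OC)c(=O)c2c1`. Its difference from compound 3 is hydrogen in place of benzyl on a saturated chain carbon, two bonds along the chain from an oxygen on an aromatic ring. In words, this is hydrogen in place of benzyl on a saturated chain carbon, two bonds along the chain from an oxygen on an aromatic ring, which also reads as phenethyl to methyl.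

Within the data shown here, only one measured step involves a change in this chain: a 2.3-fold higher number from compound 2 to compound 3 (0.35 log units; beyond the scatter). That step is modest, and it is a different change from the one made here, so it offers only a rough guide to size and none to direction. On this evidence, no step beyond the usual scatter is expected in this assay. The estimated step is a 1.1-fold higher number from compound 3 to compound 4 (0.02 log units; within the scatter). The result could also turn out to be a limit rather than a number. For compound 4 the expected value is 18000 nM, with an estimated range from 9000 nM to 32000 nM.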

Compound 4, half-maximal effective concentration: > 20000 nM
Compound 4: a limit, no number; the forecaster's own chance of this, stated with the estimate: 45%; at least 1.1-fold (0.04 log units) between middle value and limit.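

In this assay compound 4 gives > 20000 nM, which is a limit of the assay and not a number. Losing the benzyl gives an at least 1.1-fold higher number from compound 3 to compound 4 (0.06 log units; that floor lies within the scatter), a floor that does not on its own separate the two compounds, whereas the comparison with the shorter benzyl-bearing compound gives an at least 2.6-fold higher number from compound 2 to compound 4 (0.42 log units; beyond the scatter), so the ethoxy compound clearly sits on the high side of compound 2 and, among these compounds, a high number at this position does not need a phenyl group on the chain. The step from compound 1 to compound 4 cannot be read, because both of its values are limits: the limit of > 20000 nM in this assay, at which 2 of the 4 values shown sit.

Going by these compounds, how far the true value of compound 4 lies past its limit stays open, and with it the real size of the step from compound 3. Also open, on these data alone, is what happens in this same assay with an amine, a carboxylic acid or a longer chain without any aromatic ring in place of the benzyl.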